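The source may hold more compounds than are shown below. What is called first, only, known or untested is meant among the compounds shown, and "the series" means these compounds.

Compounds measured so far:
- compound 1, `CN(C)C(=O)c1cccnc1NCCCN1CCN(c2ccccc2OCC(F)(F)F)CC1`: 15.9 nM
- compound 2, `CN(C)C(=O)c1cccnc1NCCCN1CCN(c2ccccc2OCC(C)(C)C)CC1`: 50.1 nM
- compound 3, `Cc1ccccc1N1CCN(CCCNc2ncccc2C(=O)N(C)C)CC1`: 10 nM

All three were tested in a functional assay on aorta for antagonist activity at Alpha-1D adrenergic receptor (Rattus norvegicus); on this read-out lower numbers stand for tighter binding and higher numbers for weaker binding. Compound 3 has the lowest number of the three, but its gap to compound 1 is within the scatter, so the two cannot be ranked; only compound 2 stands clearly apart, as a 5.0-fold lower number from compound 2 to compound 3 (0.70 log units; beyond the scatter) shows.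

Compound 4, `CN(C)C(=O)c1cccnc1NCCCN1CCN(c2ccccc2Cc2ccccc2)CC1`, has not yet been measured. It differs from compound 3 by phenyl in place of hydrogen on a saturated chain carbon bound to an aromatic carbon. Going by the values given here, two measured steps bear on this: a 3.2-fold higher number from compound 1 to compound 2 (0.50 log units; beyond the scatter), where a bulkier group on the same side chain gave a weaker result, and a 5.0-fold lower number from compound 2 to compound 3 (0.70 log units; beyond the scatter), where removing a large group helped. Adding bulk at this position is therefore expected to raise the number modestly, a step of about a 3.0-fold higher number from compound 3 to compound 4 (0.48 log units; beyond the scatter). Compound 4 is estimated at 30 nM, within a range from 10 nM to 100 nM.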

Compound 4, dissociation constant: 79.4 nM
For compound 4 the middle estimate is 2.6-fold (0.42 log units) below the measured one; low and high end bracket the measured number.
By their numbers in this assay, from the lowest: compounds 3 and 1 (each within the scatter of the next); then compounds 2 and 4 (each within the scatter of the next).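

Adding phenyl on a saturated chain carbon bound to an aromatic carbon clearly weakens the result, with a 7.9-fold higher number from compound 3 to compound 4 (0.90 log units; beyond the scatter), and swapping 2,2,2-trifluoroethoxy for benzyl does too, with a 5.0-fold higher number from compound 1 to compound 4 (0.70 log units; beyond the scatter). Benzyl and neopentyloxy cannot be ranked, with a 1.6-fold higher number from compound 2 to compound 4 (0.20 log units; within the scatter), so a carbon-only ring and a branched ether chain give matching results here. Nothing shown offers a reason for these differences. Going by these compounds, whether an ethyl group, or a pyridine ring in place of the phenyl, would stay close to compound 3 remains open.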